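The source may hold more compounds than are shown below. What is called first, only, known or untested is meant among the compounds shown, and "the series" means these compounds.

Working notes on the series so far.

Two compounds carry numbers. Going by the values given here, compound 1 `Cn1c(=O)c(S(=O)(=O)c2ccc(F)cc2[N+](=O)[O-])cc2cnc(Nc3ccc4[nH]ccc4c3)nc21` is the one with the lower number: in a functional assay on K562 cells (Homo sapiens) for inhibition, read by trypan blue exclusion, with a stated time of 72 h (on this read-out higher numbers stand for weaker inhibition and lower numbers for stronger inhibition), compound 1 gives 900 nM. Compound 2 `Cn1c(=O)c(S(=O)(=O)c2ccc(F)cc2F)cc2cnc(Nc3ccc4[nH]c(C(=O)O)cc4c3)nc21` differs from compound 1 at more than one place; in this assay compound 2 gives a higher number, 10000 nM, and the gap between the two lies beyond the usual scatter. Among the compounds with values here, as only one place differs between compound 1 and compound 3, compound 2 offers no single step to borrow from.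

Compound 3 `Cn1c(=O)c(S(=O)(=O)c2ccc([N+](=O)[O-])cc2F)cc2cnc(Nc3ccc4[nH]ccc4c3)nc21` has not been measured. It has the same atoms as compound 1, joined differently: 2-fluoro-4-nitrophenyl in place of 4-fluoro-2-nitrophenyl on a sulfonyl sulfur. The fluorine and the nitro group simply trade places on the ring attached to the sulfonyl sulfur.

Within the data shown here, no measured pair shows this exchange, so the size of the step is open. Swapping two substituents within one ring usually moves the number only modestly; the expected step is a 1.7-fold higher number from compound 1 to compound 3 (0.22 log units; within the scatter), towards weaker inhibition but close to the edge of the scatter. Compound 3 is therefore estimated at 1500 nM in this assay, with a range from 400 nM to 6000 nM.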

Compound 3, half-maximal inhibitory concentration: 200 nM
For compound 3 the middle estimate is 7.5-fold (0.88 log units) above the measured one, and the stated range ends above it.
By their numbers in this assay, from the lowest: compound 3; then compound 1; then compound 2.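

Going by these compounds alone, this is the first single-place step, and it shows that the aryl group on the sulfonyl sulfur is sensitive to the arrangement of its two substituents. In this assay, 2-fluoro-4-nitrophenyl in place of 4-fluoro-2-nitrophenyl gives a 4.5-fold lower number from compound 1 to compound 3 (0.65 log units; beyond the scatter), although the heavy-atom, donor and acceptor counts of the two groups are identical; compound 2 could not show this, as it differs from compound 1 at more than one place. Nothing measured here bears on the reason for this step.

On these data alone, it remains open whether the step follows the nitro group or the fluorine, and an amine or a nitrile in place of the nitro group of compound 3 would help separate the two. Also open is whether the same exchange gives a step of similar size alongside the carboxylic acid carried by compound 2, as no single-place pair containing that group is shown.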